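Ring-nitrogen repositioning in a diaryl urea series

The compounds below may be only part of what the source reports. "The series", "measured", "known", "first", "only" and "open" are said of these compounds alone.

Measured compounds in a functional assay on Bel-7402 cells (Homo sapiens) for cytotoxicity, read by MTT assay, with a stated time of 72 h; on this read-out lower numbers stand for stronger inhibition and higher numbers for weaker inhibition:
Compound 1 `Cc1cccc2c1cnn2-c1ccc(NC(=O)Nc2ccc(Cl)c(C(F)(F)F)c2)cc1`: 6700 nM
Compound 2 `O=C(Nc1ccc(-n2ncc3ccncc32)cc1)Nc1ccc(Cl)c(C(F)(F)F)c1`: 4000 nM

In this assay compound 2 gives 4000 nM and compound 1 gives 6700 nM; the two numbers lie within the scatter of each other, so neither can be placed ahead of the other. Within the data shown here, the only measured step, a 1.7-fold lower number from compound 1 to compound 2 (0.22 log units; within the scatter), is itself within the scatter.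

Compound 3 `O=C(Nc1ccc(-n2ncc3cccnc32)cc1)Nc1ccc(Cl)c(C(F)(F)F)c1` carries the change (a group of 9 heavy atoms (6 carbon, 3 nitrogen; one five-membered aromatic ring with 2 hetero atoms, one six-membered aromatic ring with 1 hetero atom) in place of a group of 9 heavy atoms (6 carbon, 3 nitrogen; one five-membered aromatic ring with 2 hetero atoms, one six-membered aromatic ring with 1 hetero atom), on an aromatic carbon). Among the measured compounds shown here, no measured step moves a ring nitrogen within a group of this kind, and the single step in hand shows the series tolerating a swap at this position without a shift beyond the scatter. The expectation for compound 3 is therefore a step of no change at the digits printed from compound 2 to compound 3 (within the scatter), that is, no movement beyond the scatter. Compound 3 is estimated at 4000 nM, with a range from 1500 nM to 11000 nM.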

Compound 3, half-maximal inhibitory concentration: 20900 nM
The estimate for compound 3 lay 5.2-fold (0.72 log units) below the measured number; the whole stated range lies below it.
By their numbers in this assay, from the lowest: compounds 2 and 1 (each within the scatter of the next); then compound 3.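

In this assay, this position responds to where the ring nitrogen sits, not only to which group is present: with the same atoms joined differently, the move is beyond the scatter (a 5.2-fold higher number from compound 2 to compound 3 (0.72 log units; beyond the scatter)). The change from the group with a six-membered aromatic ring of carbon only is also beyond the scatter in this arrangement (a 3.1-fold higher number from compound 1 to compound 3 (0.49 log units; beyond the scatter)), unlike the earlier step. No evidence on the origin of this difference is available.

Open, from the compounds shown here alone, is how the series would respond to an amine or a carboxylic acid on this group. Also open, going by these compounds, is whether any other ring-nitrogen arrangement would give a lower number.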